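A few compounds are considered here, and "the series" means these few. Any claim that something is new, unique, unknown or untested is made for them only; others in the source may bear on it.

Compound 1 `O=C(O)CC(NS(=O)(=O)c1ccc(F)cc1)c1ccccc1`: > 100000 nM
Compound 2 `O=C(O)CC(NS(=O)(=O)c1ccc(C(F)(F)F)cc1)c1ccccc1`: 54700 nM

These results come from a functional assay on MDA-MB-436 cells (Homo sapiens) for antiproliferative activity, read by MTT assay, with a stated time of 24 h; a higher number here means a weaker inhibitor, a lower number a stronger inhibitor. Compound 1 reads > 100000 nM, which is a limit of the assay and not a number. For the measured compounds named here, compound 2, at 54700 nM, therefore holds the only true number so far. Its standing can be judged only against that limit, (the limit of > 100000 nM in this assay, at which 1 of the 2 values shown sits).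

Compound 3 `O=C(O)CC(NS(=O)(=O)c1ccc(C(F)(F)F)cc1)c1ccc(Cl)cc1Cl` keeps everything in compound 2 except one group, (2,4-dichlorophenyl in place of phenyl on a saturated chain carbon bound to a saturated chain carbon and a sulfonamide nitrogen). In words, 2,4-dichlorophenyl stands in place of phenyl on a saturated chain carbon bound to a saturated chain carbon and a sulfonamide nitrogen.

Going by the values given here, only one measured step exists, and it lies at a different place: trifluoromethyl in place of fluoro on an aromatic carbon gave an at least 1.8-fold lower number from compound 1 to compound 2 (0.26 log units; that floor lies within the scatter). No measurement tests the new change directly, so that step is only a weak guide to its size. Starting from compound 2 at 54700 nM, a modest move towards a lower number is expected, though this is a judgement more than a finding.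

The estimated step is a 2.2-fold lower number from compound 2 to compound 3 (0.34 log units; beyond the scatter).

For compound 3 the expected value is 25000 nM, with an estimated range of 7000 nM to 90000 nM.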

Compound 3, half-maximal inhibitory concentration: 37600 nM
For compound 3 the middle estimate is 1.5-fold (0.18 log units) below the measured one; measured number inside the range.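

In this assay, 2,4-dichlorophenyl in place of phenyl on a saturated chain carbon bound to a saturated chain carbon and a sulfonamide nitrogen gives a 1.5-fold lower number from compound 2 to compound 3 (0.16 log units; within the scatter), so this change cannot be told apart from no change at all. For the compounds shown here, the only earlier step lay at a different place, so this is the first reading at this position: the ring here can carry the chlorine atoms, taking the group from the 6 heavy atoms of phenyl to 8, and the result is still a true number and not a limit of the assay. The compounds shown offer no measured property that could account for this result, and the size of the step gives little that needs accounting for.

As far as these compounds go, with both chlorine atoms entering together, the contribution of each remains unknown, and a single chlorine on the ring could read differently from the pair. Also open, from the compounds shown here alone, is how a quite different group at this position, such as an amine or a methoxy group, would read, and whether an amide in place of the carboxylic acid of the shared core would change the number.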